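The source may report more compounds than this note shows. Statements on the series, on what has been measured and on what is new or still open speak of the compounds shown alone.

Measured compounds in an ADME assay on microsomes from liver (Homo sapiens) for metabolic stability; on this read-out higher numbers stand for fast clearance and lower numbers for slow clearance:

- compound 1, `CCC(Oc1ccc(-n2cc(C(F)(F)F)cn2)cc1)c1ccc(C(=O)NCCC(=O)O)cc1`: < 8 mL/min/kg (a limit of the assay, not a number)
- compound 2, `O=C(O)CCNC(=O)c1ccc(C(Oc2ccc(-n3cc(C(F)(F)F)cn3)cc2)C2CCCC2)cc1`: 22 mL/min/kg
- compound 3, `CCCC(Oc1ccc(-n2cc(C(=O)N(C)C)cn2)cc1)c1ccc(C(=O)NCCC(=O)O)cc1`: < 13 mL/min/kg (a limit of the assay, not a number)

Compound 3 therefore stands at the lower edge of what this assay reports. Its value is a limit, as is the value of compound 1 (the limit of < 8 mL/min/kg in this assay, at which 1 of the 3 values shown sits); only compound 2 has a measured number. Among the measured compounds shown here, the one step that is measured, an at least 2.7-fold higher number from compound 1 to compound 2 (0.43 log units; beyond the scatter), concerns the saturated chain carbon and not the pyrazole ring, so it does not bear directly on the change that leads to compound 4.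

Compound 4, `CCCC(Oc1ccc(-n2cc3ccccc3n2)cc1)c1ccc(C(=O)NCCC(=O)O)cc1`, differs from compound 3 in one place: 2H-indazol-2-yl in place of 4-(dimethylcarbamoyl)-1H-pyrazol-1-yl on an aromatic carbon. For the measured compounds named here, no measured pair shows the effect of swapping one heteroaromatic ring for another at this aromatic carbon, so the expectation rests on the position of compound 3 alone (the limit of < 13 mL/min/kg in this assay, at which 1 of the 3 values shown sits). Because compound 3 gives < 13 mL/min/kg, a limit, a rise of modest size is expected but cannot be anchored to a firm starting number; the expected step is an at least 1.5-fold higher number from compound 3 to compound 4 (0.18 log units; that floor lies within the scatter). For compound 4 the estimate in this assay is 20 mL/min/kg, with a range from 8 mL/min/kg to 50 mL/min/kg.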

Compound 4, clearance: 44 mL/min/kg
Compound 4: middle estimate off by 2.2-fold (0.34 log units), on the low side, within the range that was stated.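

In this assay, replacing 4-(dimethylcarbamoyl)-1H-pyrazol-1-yl with 2H-indazol-2-yl on this aromatic carbon gives an at least 3.3-fold higher number from compound 3 to compound 4 (0.52 log units; beyond the scatter). Among the compounds shown here, the only step measured earlier concerned the saturated chain carbon, so this is the first sign that the read-out also responds to a change at the aromatic carbon para to a large group. The step is a floor and not an exact size, since the value of compound 3 is a limit of the assay: the limit of < 13 mL/min/kg in this assay, at which 1 of the 4 values shown sits.

The change removes the dimethylcarbamoyl group and brings in a six-membered aromatic ring of carbon only in a single move, so the compounds shown cannot say which of these two parts goes with the higher clearance. An unsubstituted 1H-pyrazol-1-yl group at the same aromatic carbon on the same core would help to separate them, and a pyrazole carrying a nitrile would show whether a small group in place of the dimethylcarbamoyl group gives a read-out closer to compound 3 or to compound 4.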